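This account rests on a few compounds, and the source may have more. Where it says the series, first, only, none or still open, it means among the compounds named here.

Working notes on the series. Compound 3 `Cc1cc(/C=C/C#N)cc(C)c1Oc1cc(Nc2ccc(C#N)cc2)c(N)cc1C(=O)NCCC(F)F` gives 0.233 h in an ADME assay on liver (Homo sapiens) for metabolic stability, read by LC-MS, using S9 fraction and NADPH, with a stated time of 45 min, tested at 1 uM (on this read-out higher numbers stand for a longer-lived compound and lower numbers for a shorter-lived compound), the second highest of the three numbers: compound 1 `COCCOC(=O)c1cc(N)c(Nc2ccc(C#N)cc2)cc1Oc1c(C)cc(/C=C/C#N)cc1C` gives 0.158 h, within the scatter of compound 3, while compound 2 `CCNC(=O)c1cc(N)c(Nc2ccc(C#N)cc2)cc1Oc1c(C)cc(/C=C/C#N)cc1C` gives 1.02 h, with a 4.4-fold lower number from compound 2 to compound 3 (0.64 log units; beyond the scatter). Compound 4 `COC(=O)c1cc(N)c(Nc2ccc(C#N)cc2)cc1Oc1c(C)cc(/C=C/C#N)cc1C` differs from compound 3 by methoxy in place of (3,3-difluoropropyl)amino on a carbonyl carbon. Within the data shown here, the step that bears on it most directly is a 1.5-fold higher number from compound 1 to compound 3 (0.17 log units; within the scatter); compound 1 carries 2-methoxyethoxy on the same carbonyl carbon, whereas a 6.5-fold higher number from compound 1 to compound 2 (0.81 log units; beyond the scatter) marks the only change beyond the scatter seen here. Compound 4 is therefore expected to sit near compound 1 and below compound 2, with a 1.4-fold lower number from compound 3 to compound 4 (0.14 log units; within the scatter) as the estimated step. The expected value for compound 4 is 0.17 h, in a range from 0.07 h to 0.4 h.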

Compound 4, half-life: 0.128 h
Beside the measured number, compound 4's estimate is 1.3-fold (0.12 log units) above it, within the range that was stated.
By their numbers in this assay, from the lowest: compounds 4, 1 and 3 (each within the scatter of the next); then compound 2.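

In this assay methoxy on the carbonyl carbon shows an 8.0-fold lower number from compound 2 to compound 4 (0.90 log units; beyond the scatter) and so stays apart from ethylamino. Shortening 2-methoxyethoxy to methoxy gives a 1.2-fold lower number from compound 1 to compound 4 (0.09 log units; within the scatter) and replacing (3,3-difluoropropyl)amino with methoxy gives a 1.8-fold lower number from compound 3 to compound 4 (0.26 log units; within the scatter) and both steps lie within the scatter. An amide-type nitrogen on this carbon therefore does not by itself set a compound apart: compound 3 goes against that pattern, staying within the scatter of compound 1 and compound 4, and only compound 2 stands clear. Open, as far as these compounds go, is how a carboxylic acid or an unfluorinated propylamino group would read on this carbonyl carbon. Nothing shown gives a reason for these steps.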